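The source may report more compounds than this note shows. Statements on the series, on what has been measured and on what is new or still open speak of the compounds shown alone.

Working notes on the acetanilide-type amide series sharing the core shown in compound 1 `COc1ccc(CN(C(C)=O)c2cc(OC)c(OC)c(OC)c2)cc1O`.

Two members are measured. In a functional assay on MGC-803 cells (Homo sapiens) for inhibition, read by MTT assay, with a stated time of 48 h (a higher number here means a weaker inhibitor, a lower number a stronger inhibitor), compound 1 gives 79 nM. Compound 2 `COc1ccc(CN(C(=O)C(C)C)c2cc(OC)c(OC)c(OC)c2)cc1O`, which carries the isopropyl in place of the methyl on the carbonyl carbon, gives 210 nM in this assay. Within the data shown here, the only step so far is a 2.7-fold higher number from compound 1 to compound 2 (0.42 log units; beyond the scatter), so compound 2 stands at the higher of the two numbers, with compound 1 as its nearest and only neighbour.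

The next compound, compound 3 `COc1ccc(CN(C(=O)CBr)c2cc(OC)c(OC)c(OC)c2)cc1O`, departs from compound 2 by bromomethyl in place of isopropyl on a carbonyl carbon. Among the measured compounds shown here, no measured step involves a bromomethyl group, so only the methyl-to-isopropyl step bears on it, and only loosely: it showed that enlarging the group on the carbonyl carbon raised the number in this assay by a modest, real amount. Going from isopropyl to a group with fewer heavy atoms is expected to run the other way, toward the number of compound 1, though with little certainty. The step of a 1.9-fold lower number from compound 2 to compound 3 (0.28 log units; within the scatter) is therefore the expectation, and compound 3 is estimated at 110 nM in this assay, within 40 nM to 320 nM.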

Compound 3, half-maximal inhibitory concentration: 140 nM
Estimate against measurement, compound 3: 1.3-fold (0.10 log units) below; low and high end bracket the measured number.
By their numbers in this assay, from the lowest: compounds 1, 3 and 2 (each within the scatter of the next, the first and the last beyond it).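

In this assay, the change from isopropyl to bromomethyl on a carbonyl carbon gives a step within the scatter (a 1.5-fold lower number from compound 2 to compound 3 (0.18 log units; within the scatter)), and bromo in place of hydrogen on a saturated chain carbon bound to a carbonyl carbon does the same (a 1.8-fold higher number from compound 1 to compound 3 (0.25 log units; within the scatter)). The series therefore gains its first group at this position with an atom other than carbon, and that bromine leaves the number unresolved from both neighbours, even though the two earlier members remain separated beyond the scatter (a 2.7-fold higher number from compound 1 to compound 2 (0.42 log units; beyond the scatter)). Nothing available here accounts for these numbers.

With only methyl, isopropyl and bromomethyl at this position, the three compounds are too few to show whether the number follows the size of the group or the presence of bromine, and a chloromethyl group or a longer chain would bear on that question. From the compounds shown here alone, whether an aminomethyl group or a ring on the carbonyl carbon would move the number beyond the scatter in either direction also stays open.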